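A few compounds are considered here, and "the series" means these few. Any claim that something is new, unique, unknown or untested is made for them only; others in the source may bear on it.

Within the data shown here, the two measured members share one core and differ only in the amide portion. Compound 1 `C[C@H](C#Cc1cccc(C(=O)NCC[C@@H](c2ccc(F)cc2)c2ccc(C(F)(F)F)cc2)c1)N(O)C(N)=O` carries the longer, branched amine portion, and in an assay for inhibition of Polyunsaturated fatty acid 5-lipoxygenase (Homo sapiens), read by HPLC, with stated times of 15 min and 10 min (on this read-out lower numbers stand for stronger inhibition and higher numbers for weaker inhibition), compound 1 gives 160 nM. Compound 2 `CC(C#Cc1cccc(C(=O)NCc2ccccc2OC(F)(F)F)c1)N(O)C(N)=O` carries a benzyl amide bearing trifluoromethoxy, and in this assay compound 2 gives 1000 nM. Compound 2 therefore stands at the higher of the two numbers; its nearest neighbour, compound 1, sits lower by a margin beyond the usual scatter, so the two are not interchangeable on this read-out.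

Compound 3 `CC(C#Cc1cccc(C(=O)NCc2ccccc2C(F)(F)F)c1)N(O)C(N)=O` is the next point: trifluoromethyl in place of trifluoromethoxy on an aromatic carbon. Among the measured compounds shown here, no measured pair in the set isolates this exchange, so nothing in the numbers fixes its direction. The change is confined to a single group on one aromatic carbon, well away from the core, and on that footing no step beyond the scatter is expected; the step from compound 2 to compound 3 is estimated as a 1.1-fold lower number from compound 2 to compound 3 (0.05 log units; within the scatter). Accordingly compound 3 is expected to give 900 nM in this assay, with a range of 350 nM to 2500 nM.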

Compound 3, half-maximal inhibitory concentration: 700 nM
The estimate for compound 3 lay 1.3-fold (0.11 log units) above the measured number; measured number inside the range.
By their numbers in this assay, from the lowest: compound 1; then compounds 3 and 2 (each within the scatter of the next).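

Among these compounds, compounds 2 and 3 form the first pair that isolates a single exchange: trifluoromethyl in place of trifluoromethoxy, on an aromatic carbon ortho to a large group, reads in this assay as a 1.4-fold lower number from compound 2 to compound 3 (0.15 log units; within the scatter). This step lies within the scatter, so the read-out does not separate the two groups at this carbon, and the oxygen that leaves with trifluoromethoxy has no effect here that can be distinguished from repeat variation. No available measurement offers an explanation for this outcome.

The compounds shown leave open whether this carbon would respond in the same way to a group of another kind, such as methoxy, a nitrile, a chlorine atom or plain hydrogen, since both groups compared here are fluorinated. They also leave open whether the same exchange would give a step within the scatter on an aromatic carbon elsewhere in the benzyl amide, or in the longer, branched amine portion of compound 1.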